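The source may hold more compounds than are shown below. What is called first, only, known or untested is meant among the compounds shown, and "the series" means these compounds.

Values in a functional assay on PC-12 cells (Rattus norvegicus) for cytotoxicity, read by MTT assay, with stated times of 2 h and 24 h, tested at 5 uM; a lower number here means a weaker effect, a higher number a stronger effect of the compound at the concentration tested:
compound 1 `CC(C)c1ccc(-n2nc(-c3ccc(C(F)(F)F)cc3O)nc2-c2ccccc2O)cc1`: 100%
compound 2 `Oc1cc(C(F)(F)F)ccc1-c1nc(-c2ccccc2O)n(-c2ccc(Cl)cc2)n1`: 87.3%
compound 3 `Cc1ccc(-n2nc(-c3ccc(C(F)(F)F)cc3O)nc2-c2ccccc2O)c(C)c1`: 93.3%

Compound 1 has the highest of the three numbers. Nearest is compound 3, a number 6.7 percentage points lower from compound 1 to compound 3 (within the scatter), which stays within the scatter. Furthest is compound 2, a number 12.7 percentage points lower from compound 1 to compound 2 (beyond the scatter), which lies beyond it. Between compound 2 and compound 3 the difference is a number 6 percentage points higher from compound 2 to compound 3 (within the scatter), within the scatter.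

Compound 4 `Oc1cc(C(F)(F)F)ccc1-c1nc(-c2ccccc2O)n(-c2ccc(F)cc2F)n1` is not yet measured in this assay. It differs from compound 1 in one place: 2,4-difluorophenyl in place of 4-isopropylphenyl on an aromatic nitrogen. For the measured compounds named here, two measured steps bear on this change. The step of a number 12.7 percentage points lower from compound 1 to compound 2 (beyond the scatter) exchanges isopropyl for chloro on an aromatic carbon and gave a modest drop. The step of a number 6.7 percentage points lower from compound 1 to compound 3 (within the scatter) replaces 4-isopropylphenyl by 2,4-dimethylphenyl, whose two groups stand at the same ring positions as the two fluorines of 2,4-difluorophenyl, and stayed within the scatter. Compound 4 joins both features, halogen substitution and that two-group pattern, so a small drop from compound 1 is expected, roughly of the size seen with compound 2 and with the range reaching up to no change. Compound 4 is expected to give 88%, between 72% and 100%. The expected step is a number 12 percentage points lower from compound 1 to compound 4 (beyond the scatter).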

Compound 4, a percentage reported as activity, at one concentration (the size of the read-out at that concentration, not a potency): 83.5%
Estimate against measurement, compound 4: 4.5 percentage points above; the range from low to high includes it.
By their numbers in this assay, from the lowest: compounds 4, 2, 3 and 1 (each within the scatter of the next, the first and the last beyond it).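

In this assay, 2,4-difluorophenyl on the aromatic nitrogen in place of 4-isopropylphenyl gives a number 16.5 percentage points lower from compound 1 to compound 4 (beyond the scatter), so a second halogen-bearing aryl group at this position now stands apart from the isopropyl reference, while the dimethyl-bearing group of compound 3 does not. The two halogen-bearing groups cannot be told apart here, with a number 3.8 percentage points lower from compound 2 to compound 4 (within the scatter), and the fluorine and methyl versions of the same two-group pattern also stay together, with a number 9.8 percentage points lower from compound 3 to compound 4 (within the scatter), although that step lies close to the edge of the scatter. No measurement is available that explains these differences.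

Still open is whether an unsubstituted phenyl on the aromatic nitrogen would group with the halogen-bearing or the alkyl-bearing aryl groups, and whether an amine, a carboxylic acid or a longer chain on this ring would move the read-out further than the groups shown. The trifluoromethyl and both hydroxyl groups are the same in all of these compounds, so what they contribute to the read-out cannot be judged from this set.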